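A few compounds are considered here, and "the series" means these few. Any claim that something is new, unique, unknown or untested is made for them only; others in the source may bear on it.

Compound 3 `CCN(CC)c1ccc(/C=C2\C(=O)N(C3CCCCC3)C(=S)N2C)c(O)c1` gives 1660 nM in an assay on isolated protein for inhibition of NADPH oxidase 2 (Homo sapiens), read by chemiluminescence, in the presence of a further agent that is not named here; a lower number here means a stronger inhibitor, a higher number a weaker inhibitor. Compound 2 `CCN(CC)c1ccc(/C=C2\C(=O)N(c3ccccc3)C(=S)N2C)c(OC)c1` gives 1470 nM and compound 1 `CCN(CC)c1ccc(/C=C2\C(=O)N(c3ccccc3)C(=S)N2C)cc1` gives 1960 nM in this assay, so the three numbers sit close to one another and none is separated from the others beyond the scatter. Compound 4 `CCN(CC)c1ccc(/C=C2\C(=O)N(c3ccccc3)C(=S)N2C)c(O)c1` differs from compound 3 by phenyl in place of cyclohexyl on an amide-type nitrogen in a ring. Among the measured compounds shown here, the one measured step, a 1.3-fold lower number from compound 1 to compound 2 (0.12 log units; within the scatter), concerns a methoxy group on an aromatic carbon and does not bear on an exchange at the ring nitrogen. What can be drawn on is that compound 1 and compound 2 carry the phenyl that enters in compound 4 while compound 3 carries the cyclohexyl, and their values lie within the scatter of each other. The step from compound 3 to compound 4 is therefore expected to be a 1.0-fold lower number from compound 3 to compound 4 (0.02 log units; within the scatter), no more than the scatter. Compound 4 is estimated at 1600 nM, with a range from 700 nM to 3600 nM.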

Compound 4, half-maximal inhibitory concentration: 910 nM
Estimate against measurement, compound 4: 1.8-fold (0.25 log units) above, and the stated range covers the measured number.
By their numbers in this assay, from the lowest: compounds 4, 2, 3 and 1 (each within the scatter of the next, the first and the last beyond it).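

In this assay, among the compounds shown here, the first measured exchange on the amide-type nitrogen, phenyl in place of cyclohexyl, gives a 1.8-fold lower number from compound 3 to compound 4 (0.26 log units; within the scatter), so this change does not move the number beyond the scatter when the hydroxy group is present. For the compounds shown here, on the aromatic ring, hydrogen in place of methyl on the oxygen gives a 1.6-fold lower number from compound 2 to compound 4 (0.21 log units; within the scatter), whereas hydroxy in place of hydrogen on the aromatic carbon gives a 2.2-fold lower number from compound 1 to compound 4 (0.33 log units; beyond the scatter), the only one of these steps that passes the scatter, and only modestly. Nothing available here accounts for these steps.

The compounds shown leave open whether the exchange on the ring nitrogen would give a similar step in the absence of the hydroxy group. On these data alone, it also remains open how a benzyl group or a longer alkyl chain on that nitrogen, or an amine on the aromatic carbon, would compare.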